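The source may hold more compounds than are shown below. What is called first, only, known or untested is meant among the compounds shown, and "the series" means these compounds.

Compound 1 `COc1c(OCCCCN2CCNCC2)cc(O)c2c(=O)cc(-c3ccccc3)oc12` gives 1740 nM
Compound 2 `CC(C)NCCCCOc1c(O)cc(O)c2c(=O)cc(-c3ccccc3)oc12` gives "not determined" (no result reported)

Both compounds belong to a functional assay on A549 cells (Homo sapiens) for cytotoxicity, read by MTT assay, with a stated time of 48 h (a higher number here means a weaker inhibitor, a lower number a stronger inhibitor), but only compound 1 has a number there (1740 nM). Compound 2 has no result ("not determined" (no result reported)), so compound 1 cannot yet be ranked against anything.

The next compound, compound 3 `COc1c(OCCCCN2CCCC2)cc(O)c2c(=O)cc(-c3ccccc3)oc12`, keeps the core of compound 1 and changes only the group at the end of the chain: pyrrolidin-1-yl in place of piperazin-1-yl on a saturated chain carbon, four bonds along the chain from an oxygen on an aromatic ring. In words, this is pyrrolidin-1-yl in place of piperazin-1-yl on a saturated chain carbon, four bonds along the chain from an oxygen on an aromatic ring.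

Among the measured compounds shown here, no measured pair shows what this swap does, so the only anchor for the expectation is compound 1 (1740 nM). A modest loss in this assay is expected, meaning a somewhat higher number, although a step within the usual scatter would be no surprise. The estimated change is a 1.6-fold higher number from compound 1 to compound 3 (0.21 log units; within the scatter), and it carries wide uncertainty. In this assay compound 3 is estimated at 2800 nM with an expected range from 1000 nM to 8000 nM (an expectation, not a measurement).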

Compound 3, half-maximal inhibitory concentration: 1530 nM
The estimate for compound 3 lay 1.8-fold (0.26 log units) above the measured number; measured number inside the range.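

In this assay, putting pyrrolidin-1-yl in place of piperazin-1-yl gives a 1.1-fold lower number from compound 1 to compound 3 (0.06 log units; within the scatter), so the two compounds cannot be told apart. Among the compounds shown here, this is the first direct comparison at this saturated chain carbon, four bonds along the chain from an oxygen on an aromatic ring, and it shows that a five-membered ring with no hydrogen-bond donor can replace a six-membered ring that has one without a change beyond the scatter. No supporting information bears on why the swap leaves the reading so little altered.

This is one pair in one cell assay, so it cannot show whether the end of the chain matters in general or whether these two rings simply happen to read alike. Other groups at this position, such as a morpholin-4-yl ring, a piperidin-1-yl ring or a carboxylic acid, and a longer chain carrying pyrrolidin-1-yl, remain open, as does any comparison with compound 2, which has no number to read.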